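Pyrimidin-2-yl in place of pyridin-2-yl: compound 3 to compound 4

A few compounds are considered here, and "the series" means these few. Any claim that something is new, unique, unknown or untested is made for them only; others in the source may bear on it.

In a functional assay on MCF7 cells (Homo sapiens) for inhibition, read by MTT assay, with a stated time of 72 h (on this read-out lower numbers stand for stronger inhibition and higher numbers for weaker inhibition), compound 1 `CN1CCN(c2cc(C(F)(F)F)nc(SCc3ccc(C(F)(F)F)cc3)n2)CC1` gives 30200 nM and compound 2 `CCN1CCN(c2cc(C(F)(F)F)nc(SCc3ccc(C(F)(F)F)cc3)n2)CC1` gives 22000 nM, with a 1.4-fold lower number from compound 1 to compound 2 (0.14 log units; within the scatter). Compound 3 `FC(F)(F)c1ccc(CSc2nc(N3CCN(c4ccccn4)CC3)cc(C(F)(F)F)n2)cc1` reads > 50000 nM in this assay, which is a limit and not a number. Compound 3 therefore stands at the limit of > 50000 nM in this assay, at which 1 of the 3 values shown sits.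

Compound 4 `FC(F)(F)c1ccc(CSc2nc(N3CCN(c4ncccn4)CC3)cc(C(F)(F)F)n2)cc1` carries pyrimidin-2-yl in place of pyridin-2-yl on an amine nitrogen in a ring. Among the compounds with values here, no measured step exchanges one aromatic ring for another. The nearest steps put pyridin-2-yl in place of methyl, with an at least 1.6-fold higher number from compound 1 to compound 3 (0.21 log units; that floor lies within the scatter), and in place of ethyl, with an at least 2.2-fold higher number from compound 2 to compound 3 (0.35 log units; beyond the scatter). Neither gives a size for the present change, so no step beyond the scatter is expected, and a second limit reading would be no surprise. The expected step is an at least 1.1-fold lower number from compound 3 to compound 4 (0.04 log units; that floor lies within the scatter). For compound 4 the estimated value in this assay is 45000 nM, with an expected range of 20000 nM to 90000 nM.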

Compound 4, half-maximal inhibitory concentration: > 50000 nM
Compound 4 ended at the assay's limit; the forecaster's own chance of this, stated with the estimate: 55%; middle value at least 1.1-fold (0.04 log units) from the limit.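

In this assay, pyrimidin-2-yl on this amine nitrogen in a ring gives a limit and not a number, as pyridin-2-yl did: the limit of > 50000 nM in this assay, at which 2 of the 4 values shown sit.

Pyrimidin-2-yl in place of ethyl gives an at least 2.2-fold higher number from compound 2 to compound 4 (0.35 log units; beyond the scatter), and pyrimidin-2-yl in place of methyl gives an at least 1.6-fold higher number from compound 1 to compound 4 (0.21 log units; that floor lies within the scatter). The step between the two aromatic rings cannot be read, so moving from one ring nitrogen and hydrogen-bond acceptor to two has no measurable size here, and the shown aromatic rings at this position yield only limits.

From the compounds shown here alone, it remains open how a hydrogen, a longer chain such as propyl or a phenyl ring on this nitrogen would read in this assay. Going by these compounds, it also remains open whether any aromatic ring at this position can give a number and not a limit.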